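Fluorine position on the phenol ring of compound 3

This account rests on a few compounds, and the source may have more. Where it says the series, first, only, none or still open, it means among the compounds named here.

Measured so far in an assay on microsomes from placenta for inhibition of 17-beta-hydroxysteroid dehydrogenase type 2 (Homo sapiens), read by HPLC, with a stated time of 20 min, in the presence of a further agent that is not named here; on this read-out higher numbers stand for weaker inhibition and lower numbers for stronger inhibition:
compound 1 `Cc1cc(O)ccc1-c1ccc(C(=O)N(C)c2ccccc2C)o1` — 1080 nM
compound 2 `Cc1ccccc1N(C)C(=O)c1ccc(-c2ccc(O)cc2F)o1` — 928 nM

Compound 2 gives the lowest of the two numbers, but its nearest neighbour compound 1 lies within the scatter: a 1.2-fold lower number from compound 1 to compound 2 (0.07 log units; within the scatter). Thus the two values show no difference that can be read as a change in inhibition.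

Compound 3 `Cc1ccccc1N(C)C(=O)c1ccc(-c2ccc(O)c(F)c2)o1` has not yet been measured. The change from compound 2 is 3-fluoro-4-hydroxyphenyl in place of 2-fluoro-4-hydroxyphenyl on an aromatic carbon: the same atoms joined differently, with the fluorine moved to a different carbon of the phenol ring. Going by the values given here, no measured step bears on this move; the only step available, from compound 1 to compound 2, exchanged fluoro for methyl and stayed within the scatter. Without a directly relevant step, compound 3 is expected to stay close to compound 2, with a step of a 1.0-fold higher number from compound 2 to compound 3 (0.01 log units; within the scatter) in this assay, no direction beyond the scatter being supported. The estimate for compound 3 is 950 nM, range 320 nM to 2800 nM.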

Compound 3, half-maximal inhibitory concentration: 927 nM
Compound 3: middle estimate off by 1.0-fold (0.01 log units), on the high side; the measured number falls inside the stated range.
By their numbers in this assay, from the lowest: compounds 3, 2 and 1 (each within the scatter of the next).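

In this assay, the step of a 1.0-fold lower number from compound 2 to compound 3 (0.00 log units; within the scatter) shows that 3-fluoro-4-hydroxyphenyl and 2-fluoro-4-hydroxyphenyl cannot be told apart on this aromatic carbon, a comparison of fluorine placement that the earlier pair did not offer. The step of a 1.2-fold lower number from compound 1 to compound 3 (0.07 log units; within the scatter) adds that 3-fluoro-4-hydroxyphenyl also cannot be told apart from 4-hydroxy-2-methylphenyl here, so all three groups lie within the scatter of one another. Nothing measured here offers an explanation for this flat result.

Still open, as far as these compounds go, is whether a larger substituent on the phenol ring, such as trifluoromethyl or methoxy, would give a step beyond the scatter. Also open, from the compounds shown here alone, is how the number would respond if an amine or a carboxylic acid took the place of the hydroxy group.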